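Replacing the aromatic fluoro of compound 1 with hydrogen

A few compounds are considered here, and "the series" means these few. Any claim that something is new, unique, unknown or untested is made for them only; others in the source may bear on it.

Of the compounds shown here, two have numbers so far in an ADME assay on Vero cells (Chlorocebus sabaeus) for cytotoxicity; on this read-out lower numbers stand for higher toxicity in this test and higher numbers for lower toxicity in this test. Compound 1 (`O=C1C(=O)N(Cc2cn(CC(=O)N3CCN(c4cc5c(cc4F)c(=O)c(C(=O)O)cn5C4CC4)CC3)nn2)c2c(F)cccc21`) gives 8 ug/mL, the lower of the two, and compound 2 (`CCO/N=C1/C(=O)N(Cc2cn(CC(=O)N3CCN(c4cc5c(cc4F)c(=O)c(C(=O)O)cn5C4CC4)CC3)nn2)c2ccccc21`) gives 64 ug/mL, a gap beyond the usual scatter. Compound 1 therefore marks the low end of the small range seen to date in this assay. Among the compounds with values here, no pair of measured compounds differs in a single place, so the size of a one-place change has not been observed.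

Next in line is compound 3 (`O=C1C(=O)N(Cc2cn(CC(=O)N3CCN(c4cc5c(cc4F)c(=O)c(C(=O)O)cn5C4CC4)CC3)nn2)c2ccccc21`), which departs from compound 1 at one site: hydrogen in place of fluoro on an aromatic carbon. Hydrogen stands in place of fluoro on an aromatic carbon, and the rest of the structure is unchanged. Within the data shown here, with no measured step to draw on, a small move is expected, and the only higher reference, compound 2 at 64 ug/mL, tilts the expectation upward. The estimated change is a 1.8-fold higher number from compound 1 to compound 3 (0.24 log units; within the scatter), a small upward step within the scatter. For compound 3 the estimated value is 14 ug/mL, with an expected range of 5 ug/mL to 40 ug/mL.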

Compound 3, half-maximal cytotoxic concentration: 16 ug/mL
Compound 3: the middle estimate sits 1.1-fold (0.06 log units) below what was measured, within the range that was stated.
By their numbers in this assay, from the lowest: compounds 1 and 3 (each within the scatter of the next); then compound 2.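

In this assay the series now has its first one-place step, hydrogen in place of fluoro on an aromatic carbon, ortho to a fused ring and meta to a fused ring: a 2.0-fold higher number from compound 1 to compound 3 (0.30 log units; within the scatter), which lies within the scatter. At this carbon of the six-membered aromatic ring, losing the single fluorine therefore gives no separation between compound 1 and compound 3 that repeated measurement could be expected to resolve, so this change does not move the read-out by a detectable amount. No supporting data bear on this result.

From the compounds shown here alone, only fluoro and hydrogen are on record at this carbon, so it remains open whether chloro, methoxy or an amine there would also stay within the scatter of compound 1 or would shift the read-out clearly. Within the data shown here, also open is whether the same swap would read alike with other changes elsewhere on the shared core, since this single step is the only one-place comparison available so far.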